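A few compounds are considered here, and "the series" means these few. Any claim that something is new, unique, unknown or untested is made for them only; others in the source may bear on it.

Compound 1 `Cc1ccc(S(=O)(=O)N(CC(=O)NCc2ccc(Cl)cc2)c2cccnc2)cc1` is the member of this set that carries pyridin-3-yl on the sulfonamide nitrogen. In an assay on CHO cells for displacement of a labelled ligand from prostaglandin E2 receptor EP1 subtype (Homo sapiens) (on this read-out lower numbers stand for stronger inhibition and higher numbers for weaker inhibition), compound 1 gives only a limit of the assay, < 1000 nM, so its place on the numbers shown is a bound and not a point. Compound 2 `Cc1ccc(S(=O)(=O)N(CC(=O)NCc2ccc(Cl)cc2)c2ccnn2C)cc1` carries 1-methyl-1H-pyrazol-5-yl at the same nitrogen; in this assay compound 2 gives 398 nM. The step that the limit leaves unreadable from compound 1 to compound 2 cannot be read in size because the limit of < 1000 nM in this assay, at which 1 of the 2 values shown sits, sits at one of its two ends.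

Compound 3 `CCn1nccc1N(CC(=O)NCc1ccc(Cl)cc1)S(=O)(=O)c1ccc(C)cc1` is not yet measured. Against compound 1 the change is 1-ethyl-1H-pyrazol-5-yl in place of pyridin-3-yl on a sulfonamide nitrogen. Among the compounds with values here, the only measured step that bears on it, a step that the limit leaves unreadable from compound 1 to compound 2, swaps the same pyridin-3-yl for the methyl congener of the entering group, and its size is not readable. Within the data shown here, no measured step therefore fixes the size or direction of the step to be expected; the expectation leans on compound 2, whose value of 398 nM is the nearest measured point. For compound 3 the expected value in this assay is 450 nM, within 120 nM to 1600 nM, which as a step is estimated at a step that the limit leaves unreadable from compound 1 to compound 3.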

Compound 3, inhibition constant: 158 nM
The estimate for compound 3 lay 2.8-fold (0.45 log units) above the measured number, and the stated range covers the measured number.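

In this assay, 1-ethyl-1H-pyrazol-5-yl in place of 1-methyl-1H-pyrazol-5-yl on the sulfonamide nitrogen gives a 2.5-fold lower number from compound 2 to compound 3 (0.40 log units; beyond the scatter), a modest change from one added methyl on a saturated chain carbon bound to an aromatic nitrogen. Within the data shown here, this is the first readable step, showing that the number at this position responds to a small change within the substituent and not only to an exchange of the whole ring. The value of compound 1 is a limit of the assay, and the steps from compound 1 to compound 2 and to compound 3 cannot be read in size: the limit of < 1000 nM in this assay, at which 1 of the 3 values shown sits.

From the compounds shown here alone, with only the methyl and ethyl members in hand, no trend with chain length is fixed, and it remains open whether a propyl chain, an isopropyl group or a cyclopropyl group on the same ring nitrogen would lower the number further or raise it. Also open, going by these compounds, is how a hydroxyl group or an amine at the end of that chain would read in this assay.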